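One Added Methoxy on a Growth Inhibitor

The source may report more compounds than this note shows. Statements on the series, on what has been measured and on what is new or still open speak of the compounds shown alone.

Two related compounds have been measured in a functional assay on DU-145 cells (Homo sapiens) for inhibition, read by sulforhodamine B assay, with a stated time of 48 h; a lower number here means a stronger inhibitor of growth, a higher number a weaker inhibitor of growth. Compound 1 (`COc1cc(C(=O)NNC(=O)c2ccc3[nH]c(-c4ccc([N+](=O)[O-])s4)nc3c2)cc(OC)c1OC`) gives 62.5 ug/mL, while compound 2 (`COc1ccc(C(=O)NNC(=O)c2ccc3[nH]c(-c4ccc([N+](=O)[O-])o4)nc3c2)cc1OC`) gives 15.6 ug/mL. Compound 2 therefore holds the lower of the two numbers, and the gap between them lies beyond the usual scatter. These two compounds differ in more than one place, so their gap cannot be tied to any single structural change.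

The next compound, compound 3 (`COc1cc(C(=O)NNC(=O)c2ccc3[nH]c(-c4ccc([N+](=O)[O-])o4)nc3c2)cc(OC)c1OC`), departs from compound 2 in one place: methoxy in place of hydrogen on an aromatic carbon. In words, a methoxy stands in place of hydrogen on an aromatic carbon. For the measured compounds named here, no measured step shows what this change does on its own, so the expectation is tentative. The higher number of compound 1, at 62.5 ug/mL, is the only pointer available, and it leans the forecast gently upward. In this assay, a small move toward weaker inhibition of growth is expected, possibly no larger than the scatter, with an estimated 1.8-fold higher number from compound 2 to compound 3 (0.25 log units; within the scatter). The expected value for compound 3 is 28 ug/mL, with an estimated range from 11 ug/mL to 70 ug/mL.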

Compound 3, concentration for 50% growth inhibition: 15.6 ug/mL
Compound 3: the middle estimate sits 1.8-fold (0.25 log units) above what was measured; the measured number falls inside the stated range.
By their numbers in this assay, from the lowest: compounds 2 and 3 (each within the scatter of the next); then compound 1.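

In this assay, the step for methoxy in place of hydrogen on this aromatic carbon, ortho to a methoxy group and meta to a large group, reads no change at the digits printed from compound 2 to compound 3 (within the scatter), so this position can carry a methoxy without a step beyond the scatter. The compounds now also offer a reading of the other place on its own, where 5-nitrofuran-2-yl in place of 5-nitrothiophen-2-yl gives a 4.0-fold lower number from compound 1 to compound 3 (0.60 log units; beyond the scatter), and of these two single steps only this one lies beyond the scatter. No measured evidence bearing on the reason for either step is available here.

On these data alone, whether this aromatic carbon would accept a group other than methoxy in the same way, such as an amine, a carboxylic acid or a longer chain like butoxy, remains open. As far as these compounds go, the exchange of 5-nitrothiophen-2-yl for 5-nitrofuran-2-yl has also been read only with the methoxy of compound 3 in place, so its size without that methoxy is still unknown.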